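The compounds below may be only part of what the source reports. "The series", "measured", "known", "first", "only" and "open" are said of these compounds alone.

Measured compounds:
compound 1, `Cc1cc(C)c(CN2CCc3c(C)cc(O[C@@H]4CCOC4)c(Cl)c3C2=O)c(=O)[nH]1`, giving 2.1
compound 2, `Cc1cc(C)c(CN2CCc3ccc(OC(C)C)cc3C2=O)c(=O)[nH]1`, giving 2.5
compound 3, `COc1cccc(C(=O)NCc2c(C)cc(C)[nH]c2=O)c1`, giving 1.7

These three values come from a physicochemical assay for lipophilicity, at pH 7.4; a higher number here means a more lipophilic compound, a lower number a more polar compound. Compound 3 stands lowest of the three numbers: compound 1 lies nearest to it, a number higher by an amount beyond the scatter, and compound 2 lies furthest from it, higher by a still larger amount, also beyond the scatter. Among the compounds with values here, no two of the measured compounds differ in a single place, so no single step between measured compounds can be read off directly.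

Compound 4, `COc1cccc(C(=O)NCc2c(C)cc(C)[nH]c2=O)c1O`, has not yet been measured in this assay. It differs from compound 3 in one respect: hydroxy in place of hydrogen on an aromatic carbon. The new group enters on an aromatic carbon of a six-membered aromatic ring of carbon only, ortho to a large group and ortho to a methoxy group.

Within the data shown here, with no measured step of this kind among the three compounds, the expectation rests on the change itself: a hydroxy entering in place of hydrogen is expected to move the number down by a moderate amount, beyond the scatter, so that the step from compound 3 to compound 4 is estimated as a number 0.50 log units lower from compound 3 to compound 4 (beyond the scatter). For compound 4 the distribution coefficient in this assay is therefore estimated at 1.2, within a range from 0.7 to 1.7.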

Compound 4, distribution coefficient: 1.9
Compound 4: the middle estimate sits 0.70 log units below what was measured, and the stated range ends below it.
By their numbers in this assay, from the lowest: compounds 3, 4 and 1 (each within the scatter of the next, the first and the last beyond it); then compound 2.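

Hydroxy in place of hydrogen on an aromatic carbon, ortho to a large group and ortho to a methoxy group, gives the first single-place reading in this set. In this assay that reading is a number 0.20 log units higher from compound 3 to compound 4 (within the scatter). At this position, then, adding a hydroxy, with its hydrogen-bond donor and acceptor, brings no difference that can be told from the scatter of repeated measurements, something the earlier compounds could not show, as no two of them differ in a single place; nothing available here gives a reason for this result.

This single step leaves open whether hydroxy would read the same way on another carbon of this ring, or on this carbon with no methoxy group ortho to it. The compounds shown also leave open how a different group would read at this same place, such as an amine, a carboxylic acid or a longer chain like propoxy, and whether any of these would give a step beyond the scatter.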